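A few compounds are considered here, and "the series" means these few. Any claim that something is new, unique, unknown or untested is made for them only; others in the source may bear on it.

Compound 1 `CN(C)C[C@H]1CN(C)C(=O)O1` reaches only the limit > 100000 nM in an assay on CHO cells for displacement of a labelled ligand from muscarinic acetylcholine receptor M5 (Homo sapiens); on this read-out lower numbers stand for stronger inhibition and higher numbers for weaker inhibition.
Compound 2 `CN(C)C[C@@H]1CN(C)C(=O)O1` likewise reaches only the limit > 100000 nM in this assay.
Compound 3 `CN1C[C@@H](C[N+](C)(C)C)OC1=O` also reaches only the limit > 100000 nM in this assay.

Compound 3 therefore stands at the limit, and no number is known for it; the same holds for the other two compounds (the limit of > 100000 nM in this assay, at which 3 of the 3 values shown sit). Compound 4 `CN1C[C@H](C[N+](C)(C)C)OC1=O` differs from it thus: the two compounds have the same atoms and bonds and differ only in configuration as drawn: 1 of 1 stereo elements differ; a stereocentre at a saturated ring carbon is drawn S in compound 3 and R in compound 4. The closest measured step is a step that the two limits leave unreadable from compound 1 to compound 2, a change of the same kind (the fact that compounds 1 and 2 differ only in the configuration as drawn), and a step that the two limits leave unreadable from compound 2 to compound 3 is equally unreadable. Nothing measured here shows a change of configuration on this core lifting a compound off the limit. Compound 4 is expected to stay at the limit as well, an expected step that the limit leaves unreadable from compound 3 to compound 4, giving an estimate of 200000 nM within 50000 nM to 1000000 nM.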

Compound 4, inhibition constant: > 100000 nM
Compound 4 ended at the assay's limit; the forecaster's own chance of this, stated with the estimate: 90%; the middle value lies beyond the limit too.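

In this assay compound 3 and compound 4 both sit at the limit, so no step can be read between them or from compound 1 to compound 4. The compounds shown leave open what numerical value any of them has.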